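Plasma Stability of Bicyclic Diesters: Changing One Ester Group

The source may hold more compounds than are shown below. What is called first, only, known or untested is meant among the compounds shown, and "the series" means these compounds.

Compound 1, `COc1ccccc1C(=O)O[C@@H]1CO[C@H]2[C@@H]1OC[C@@H]2OC(=O)c1ccccc1OC(C)=O`, in an ADME assay on a cell-free system (plasma, Homo sapiens) for metabolic stability, with Plasma (Rattus norvegicus) as the target, read by HPLC, at pH 7.4 (a higher number here means that the compound lasts longer, a lower number that the compound disappears faster), gives 0.0578 h.
Compound 2, `CC(=O)Oc1ccccc1C(=O)O[C@H]1CO[C@H]2[C@@H]1OC[C@H]2OC(=O)c1ccc(C#N)cc1`, gives 0.0888 h in this assay.
Compound 3, `CC(=O)Oc1ccccc1C(=O)O[C@H]1CO[C@H]2[C@@H]1OC[C@H]2OC(=O)c1ccc(-c2ccccc2)cc1`, reaches only a limit of the assay, > 0.333 h.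

All three share one core and differ only in the group attached to one carbonyl carbon. Compound 3 stands at the top of the numbers shown, but its value is a limit, not a number, so the true half-life is not known (the limit of > 0.333 h in this assay, at which 1 of the 3 values shown sits). The steps towards it were an at least 5.7-fold higher number from compound 1 to compound 3 (0.76 log units; beyond the scatter) and an at least 3.7-fold higher number from compound 2 to compound 3 (0.57 log units; beyond the scatter), while a 1.5-fold higher number from compound 1 to compound 2 (0.19 log units; within the scatter).

Compound 4, `CC(=O)Oc1ccccc1C(=O)O[C@H]1CO[C@H]2[C@@H]1OC[C@H]2OC(=O)CCO[N+](=O)[O-]`, carries the change (2-(nitrooxy)ethyl in place of 4-phenylphenyl on a carbonyl carbon). This removes the 4-phenylphenyl group that accompanied both larger measured steps and puts a short chain in its place, so a decrease rather than an increase in this assay is the natural expectation, and because of an at least 5.7-fold higher number from compound 1 to compound 3 (0.76 log units; beyond the scatter) and an at least 3.7-fold higher number from compound 2 to compound 3 (0.57 log units; beyond the scatter) the step is expected to exceed the scatter. The estimated step is an at least 4.1-fold lower number from compound 3 to compound 4 (0.61 log units; beyond the scatter). Compound 4 is expected to give about 0.08 h, within a range from 0.03 h to 0.25 h, in line with the numbers of compounds 1 and 2.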

Compound 4, half-life: 0.065 h
Estimate against measurement, compound 4: 1.2-fold (0.09 log units) above; measured number inside the range.
By their numbers in this assay, from the lowest: compounds 1, 4 and 2 (each within the scatter of the next). At a limit, above all of these: compound 3.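

In this assay, this position on a carbonyl carbon now carries a group with no ring, and 2-(nitrooxy)ethyl does not separate from the aromatic groups 4-cyanophenyl and 2-methoxyphenyl: the steps are a 1.4-fold lower number from compound 2 to compound 4 (0.14 log units; within the scatter) and a 1.1-fold higher number from compound 1 to compound 4 (0.05 log units; within the scatter). An aromatic ring at this position is therefore not required for a half-life in the range of compounds 1 and 2, and among the four compounds only the 4-phenylphenyl group of compound 3 stands apart, with an at least 5.1-fold lower number from compound 3 to compound 4 (0.70 log units; beyond the scatter). The size of that step is only a lower bound, since the value of compound 3 is a limit and not a number: the limit of > 0.333 h in this assay, at which 1 of the 4 values shown sits.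

As far as these compounds go, how far the half-life of compound 3 lies beyond its limit remains unknown, as does whether its second aromatic ring or simply the larger size of its group sets it apart. A plain phenyl or a benzyl group at this position could separate those two readings, while a longer chain or a simple propyl chain without the nitrooxy end would show whether that end contributes anything at all.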